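A few compounds are considered here, and "the series" means these few. Any claim that something is new, unique, unknown or untested is made for them only; others in the source may bear on it.

Measured in an ADME assay on AGS cells (Homo sapiens) for cytotoxicity, read by neutral red uptake, with a stated time of 24 h; a lower number here means a stronger inhibitor, a higher number a weaker inhibitor:
compound 1 `CCCCCCCCCCCC(=O)Oc1c(C(C)C)cc2c3c1OC(=O)[C@@]31CCCC(C)(C)[C@@H]1CC2`: 413000 nM
compound 2 `CCCCCCCCCCCCCCCC(=O)Oc1c(C(C)C)cc2c3c1OC(=O)[C@@]31CCCC(C)(C)[C@@H]1CC2`: > 1000000 nM, a limit and not a number

Compound 2 stands at the limit of > 1000000 nM in this assay, at which 1 of the 2 values shown sits. Compound 3 `CCCCCCCC/C=C/CCCCCCCC(=O)Oc1c(C(C)C)cc2c3c1OC(=O)[C@@]31CCCC(C)(C)[C@@H]1CC2` differs from it by a group of 10 heavy atoms (10 carbon; no ring) in place of a group of 8 heavy atoms (8 carbon; no ring), on a saturated chain carbon, seven bonds along the chain from a carbonyl carbon. Among the measured compounds shown here, one measured step bears on this change: an at least 2.4-fold higher number from compound 1 to compound 2 (0.38 log units; beyond the scatter), beyond the scatter, and it too added carbons to the chain. A further step towards a higher number is therefore expected in this assay, though its size cannot be read from a limit, and a limit is the likely report. The expected step is a step that the limit leaves unreadable from compound 2 to compound 3. For compound 3 the estimated value is 1500000 nM, with an expected range of 600000 nM to 4000000 nM.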

Compound 3, half-maximal inhibitory concentration: 822000 nM
Compound 3: the middle estimate sits 1.8-fold (0.26 log units) above what was measured; the range from low to high includes it.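

In this assay, compound 3 gives a readable value although its chain is longer than that of compound 2, whose result is only a limit (an at least 1.2-fold lower number from compound 2 to compound 3 (0.08 log units; that floor lies within the scatter)). Compound 3 thus goes against the idea that adding carbons alone keeps raising the number. It is also not separated from compound 1, which has a shorter chain (a 2.0-fold higher number from compound 1 to compound 3 (0.30 log units; within the scatter)).

The compounds shown do not separate the double bond from chain length, as none is a saturated partner of compound 3. On these data alone, how an amine or a carboxylic acid at the chain end would read remains open.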